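This account rests on a few compounds, and the source may have more. Where it says the series, first, only, none or still open, it means among the compounds named here.

Working notes on the series in a functional assay on DU-145 cells (Homo sapiens) for inhibition, read by trypan blue exclusion, with a stated time of 72 h; a lower number here means a stronger inhibitor, a higher number a weaker inhibitor. Compound 1 `COc1ccc(S(=O)(=O)c2cc3cnc(Nc4ccc5[nH]ccc5c4)nc3n(C)c2=O)cc1` gives 500 nM. Going by the values given here, compound 2 `Cn1c(=O)c(S(=O)(=O)c2ccc(Br)cc2)cc2cnc(Nc3ccc4[nH]ccc4c3)nc21` gives 5000 nM, the higher of the two numbers so far, which makes it the weaker inhibitor of the pair.

Compound 3 `Cn1c(=O)c(S(=O)(=O)c2ccc(F)cc2[N+](=O)[O-])cc2cnc(Nc3ccc4[nH]ccc4c3)nc21` changes the aryl group on the sulfone of compound 2: 4-fluoro-2-nitrophenyl in place of 4-bromophenyl on a sulfonyl sulfur. In words, this is 4-fluoro-2-nitrophenyl in place of 4-bromophenyl on a sulfonyl sulfur.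

Among the compounds with values here, the only measured step that bears on this is a 10-fold higher number from compound 1 to compound 2 (1.00 log units; beyond the scatter). That step lies beyond the scatter and shows that bromo in place of methoxy on an aromatic carbon goes with the higher number. Within the data shown here, the bromo group leaves in compound 3, but no measured compound carries a nitro or fluoro group, so the direction rests on thin evidence. A move toward a lower number is expected, smaller than the measured step.

The expected step is a 2.5-fold lower number from compound 2 to compound 3 (0.40 log units; beyond the scatter). Compound 3 is estimated at 2000 nM, with an expected range of 400 nM to 10000 nM.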

Compound 3, half-maximal inhibitory concentration: 1500 nM
Compound 3: the middle estimate sits 1.3-fold (0.12 log units) above what was measured; measured number inside the range.
By their numbers in this assay, from the lowest: compound 1; then compound 3; then compound 2.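

In this assay, the aryl group on the sulfonyl sulfur accepts a disubstituted ring: 4-fluoro-2-nitrophenyl in place of 4-bromophenyl gives a 3.3-fold lower number from compound 2 to compound 3 (0.52 log units; beyond the scatter) and so recovers part of what the bromo compound lost. The same group in place of 4-methoxyphenyl gives a 3.0-fold higher number from compound 1 to compound 3 (0.48 log units; beyond the scatter) as a step, which places compound 3 between the other two, with every gap among the three beyond the scatter; this position therefore grades the number over more than two levels, though the 4-methoxyphenyl of compound 1 remains the best of the aryl groups shown, and the fluoro and nitro groups enter together, so the step from the bromo compound cannot be divided between them. No measurement on these compounds accounts for the differences.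

The compounds shown leave open how a 4-fluorophenyl or a 2-nitrophenyl group alone would read, and either would separate the two contributions. Also open, as far as these compounds go, is whether an amine or a carboxylic acid on this aryl ring would reach or pass the number of compound 1 at 500 nM in this assay or fall back toward the weaker compounds.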